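A few compounds are considered here, and "the series" means these few. Any claim that something is new, unique, unknown or untested is made for them only; others in the source may bear on it.

In an assay on isolated protein for inhibition of long-chain fatty acid transport protein 1 (Mus musculus) (on this read-out lower numbers stand for stronger inhibition and higher numbers for weaker inhibition), compound 1 `CCn1c(CNc2ccccc2)nnc1SCC(=O)Nc1ccc(C(=O)NC)cc1` gives only a limit of the assay, > 10000 nM. Compound 2 `CCOC(=O)c1ccc(NC(=O)CSc2nnc(CSCc3ccccc3)n2CC)cc1`, a second member of the set, likewise gives only a limit in this assay, > 10000 nM. Both results sit at the limit of > 10000 nM in this assay, at which 2 of the 2 values shown sit, so compound 1 stands at that limit rather than at any number within the measured scale. Compound 3 `CCn1c(CNc2ccccc2)nnc1SCC(=O)Nc1ccc(OC)cc1` has not yet been measured in this assay. It differs from compound 1 by methoxy in place of methylcarbamoyl on an aromatic carbon. For the measured compounds named here, no step between two measured compounds is available to size this change. With compound 1 giving > 10000 nM as a limit, no direction can be read from the data, and the expected step that the limit leaves unreadable from compound 1 to compound 3 is none beyond the scatter. Compound 3 is therefore estimated at about 20000 nM, within a range from 5000 nM to 100000 nM.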

Compound 3, half-maximal inhibitory concentration: > 10000 nM
Compound 3 gave a limit, no number (the forecaster's own chance of this, stated with the estimate: 85%); the middle value is on the limit's open side.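

In this assay compound 3, like compound 1, gives only a limit and no number, so no step between the two can be read: the limit of > 10000 nM in this assay, at which 3 of the 3 values shown sit.

The compounds shown leave open how strong any of them is on the measured scale, and whether methoxy and methylcarbamoyl differ at this place.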